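This account rests on a few compounds, and the source may have more. Where it says the series, first, only, none or still open, it means among the compounds named here.

Measured so far:
compound 1 `CCOC(=O)c1ccc(-c2nn(-c3ccco3)c3ccccc23)cc1`: > 10000 nM
compound 2 `CCCOC(=O)c1ccc(-c2nn(Cc3ccccc3)c3ccccc23)cc1`: > 10000 nM

Both entries come from a functional assay on cells (Platelet, Homo sapiens) for inhibition (a lower number here means a stronger inhibitor, a higher number a weaker inhibitor), and neither is a number. Compound 1 gives only a limit of the assay, > 10000 nM. Compound 2 likewise gives only a limit, > 10000 nM, so it has no numerical position in the series. The whole record so far is the limit of > 10000 nM in this assay, at which 2 of the 2 values shown sit.

The next compound, compound 3 `CNC(=O)c1ccc(-c2nn(Cc3ccccc3)c3ccccc23)cc1`, keeps the core of compound 2 and has methylamino in place of propoxy on a carbonyl carbon, which reads as propoxycarbonyl to methylcarbamoyl: methylamino in place of propoxy on a carbonyl carbon. Among the measured compounds shown here, no measured pair shows this change, so its size in this assay cannot be read from the data.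

The expectation rests only on compound 2, whose limit of > 10000 nM gives no sign of activity to build on. The expected step, a step that the limit leaves unreadable from compound 2 to compound 3, is none beyond the scatter, with no direction favoured. Compound 3 is estimated at 15000 nM, with an expected range of 4000 nM to 60000 nM. A further reading at the limit is the likeliest outcome.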

Compound 3, half-maximal inhibitory concentration: > 10000 nM
Compound 3 ended at the assay's limit; the forecaster's own chance of this, stated with the estimate: 80%; the middle value lies beyond the limit too.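

Compound 2 and compound 3 both sit at a limit of this assay and not at a number, so no step can be read for methylamino in place of propoxy on a carbonyl carbon. The compounds shown leave open whether any change on the shared core gives a measurable value: the limit of > 10000 nM in this assay, at which 3 of the 3 values shown sit.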